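The source may hold more compounds than are shown below. What is called first, only, known or untested is meant among the compounds shown, and "the series" means these compounds.

Compound 1 `Cc1nc(C(F)(F)F)ccc1C(=O)Nc1ccc(Cl)c(-c2nc3ccccc3n2C)c1`: 9 nM
Compound 2 `Cc1nc(C(F)(F)F)ccc1C(=O)Nc1ccc(Cl)c(-c2nc3c(n2C)CCCC3)c1`: 150 nM

For the measured compounds named here, in an assay on C3H 10T1/2 cells for inhibition of Sonic hedgehog protein (Mus musculus), read by a luciferase reporter (a lower number here means a stronger inhibitor, a higher number a weaker inhibitor), compound 2 gives the highest of the two numbers; its only neighbour, compound 1, sits well apart, as the step of a 17-fold higher number from compound 1 to compound 2 (1.22 log units; beyond the scatter) shows. Compound 3 `Cc1nc(C(F)(F)F)ccc1C(=O)Nc1ccc(Cl)c(-c2nc3ccccc3s2)c1` carries the change (a group of 9 heavy atoms (7 carbon, 1 nitrogen, 1 sulfur; one five-membered aromatic ring with 2 hetero atoms, one six-membered aromatic ring of carbon only) in place of a group of 10 heavy atoms (8 carbon, 2 nitrogen; one five-membered aromatic ring with 2 hetero atoms, one six-membered non-aromatic ring of carbon only), on an aromatic carbon). Going by the values given here, the one measured step that bears on this change, a 17-fold higher number from compound 1 to compound 2 (1.22 log units; beyond the scatter), also exchanges a six-membered aromatic ring of carbon only for a non-aromatic one, but in the opposite direction; returning to an aromatic six-membered ring in compound 3 is therefore expected to give a step of about a 7.5-fold lower number from compound 2 to compound 3 (0.88 log units; beyond the scatter). Compound 3 is estimated at 20 nM, with a range from 5 nM to 80 nM.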

Compound 3, half-maximal inhibitory concentration: 70 nM
For compound 3 the middle estimate is 3.5-fold (0.54 log units) below the measured one; measured number inside the range.
By their numbers in this assay, from the lowest: compound 1; then compound 3; then compound 2.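

In this assay the 1,3-benzothiazol-2-yl group of compound 3 does not match the 1-methyl-1H-benzimidazol-2-yl group of compound 1, with a 7.8-fold higher number from compound 1 to compound 3 (0.89 log units; beyond the scatter), so this position also responds to a change in the five-membered ring, not only in the six-membered ring. The step of a 2.1-fold lower number from compound 2 to compound 3 (0.33 log units; beyond the scatter) is smaller, but it alters both rings at once and cannot be divided between them. Nothing given here explains either step. As far as these compounds go, it stays open whether 1,3-benzoxazol-2-yl or 1H-benzimidazol-2-yl would come closer to compound 1.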